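The compounds below may be only part of what the source reports. "The series", "measured", "known", "first", "only" and "open" are said of these compounds alone.

Compound 1 `COc1ccc(-c2nc(-c3ccccc3)c(-c3ccc4c(c3)NC(=O)CO4)[nH]2)cc1`: 1.2%
Compound 2 `O=C1COc2ccc(-c3nn(-c4ccc(Br)cc4)cc3-c3ccccc3)cc2N1`: 91.5%
Compound 3 `O=C1COc2ccc(-c3[nH]c(-c4ccccc4)nc3-c3ccccc3)cc2N1`: 7.6%

These three compounds were tested in a functional assay on MV4-11 cells (Homo sapiens) for cytotoxicity, read by colorimetric assay and MTT assay, with a stated time of 3 days, tested at 20 uM; a higher number here means a weaker effect of the compound at the concentration tested, a lower number a stronger effect. Compound 1 and compound 3 leave only a small fraction of the cells alive, while compound 2, the one whose core carries an extra nitrogen bearing a bromophenyl group, stands highest of the three numbers, well above compound 3 and compound 1, so it has by far the weakest effect.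

Compound 4 `O=C1COc2ccc(-c3nn(-c4ccccc4)cc3-c3ccccc3)cc2N1` is the next compound to be measured. It differs from compound 2 in one place: hydrogen in place of bromo on an aromatic carbon. Within the data shown here, only one measured step speaks to this kind of change. Going a number 6.4 percentage points higher from compound 1 to compound 3 (within the scatter) also strips a small group from a pendant phenyl ring of the core, and that change left the result essentially where it was. On that basis, no step beyond the scatter is expected in this assay from compound 2 to compound 4. Compound 4 is therefore expected to give about 88%, in a range from 70% to 100%. The expected step is a number 3.5 percentage points lower from compound 2 to compound 4 (within the scatter).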

Compound 4, a percentage reported as activity, at one concentration (the size of the read-out at that concentration, not a potency): 97.9%
Compound 4: the middle estimate sits 9.9 percentage points below what was measured; the measured number falls inside the stated range.
By their numbers in this assay, from the lowest: compounds 1 and 3 (each within the scatter of the next); then compounds 2 and 4 (each within the scatter of the next).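

In this assay, replacing the 4-bromophenyl group of compound 2 with the plain phenyl of compound 4 gives a number 6.4 percentage points higher from compound 2 to compound 4 (within the scatter) so this pair cannot be told apart. Among these compounds, the earlier step from methoxy to hydrogen concerned a different core, and this result adds a first reading for the shared core of compound 2 and compound 4: a bromo on this aromatic carbon, para to a large group, can be removed without a step beyond the usual scatter. Nothing measured here explains why the bromo makes so little difference.

As far as these compounds go, whether an amine or a carboxylic acid at this same place would move the number remains open. No single change connects these two compounds to compound 1 or compound 3, so what separates the two pairs cannot yet be read.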